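Adding a Nitrile to the Aryl Ring of Compound 2

A few compounds are considered here, and "the series" means these few. Any claim that something is new, unique, unknown or untested is made for them only; others in the source may bear on it.

Compound 2 `C[C@@H]1CN(c2cccc(NS(=O)(=O)c3ccc(-c4ccccn4)s3)c2)C[C@H](C)N1` is one of two measured members of this small series. In a functional assay for agonist activity at growth hormone secretagogue receptor type 1 (Homo sapiens), read by FLIPR (on this read-out higher numbers stand for larger maximal responses and lower numbers for smaller maximal responses), compound 2 gives 0.8, and compound 1 `COc1ccc(NS(=O)(=O)c2ccc(-c3ccccn3)s2)cc1N1C[C@@H](C)N[C@@H](C)C1` gives 0.9; the difference between them, a number 0.10 lower from compound 1 to compound 2 (within the scatter), is too small to separate the two compounds. Compound 3 `C[C@@H]1CN(c2cc(NS(=O)(=O)c3ccc(-c4ccccn4)s3)ccc2C#N)C[C@H](C)N1` has not yet been measured. It differs from compound 2 in a single place: cyano in place of hydrogen on an aromatic carbon. Among the compounds with values here, the only measured step, from compound 1 to compound 2, also alters a substituent on this same ring, and it stayed within the scatter; no measured step involves a cyano group, so the bearing is loose. The expected change no change at the digits printed from compound 2 to compound 3 (within the scatter) is therefore none beyond the scatter. Compound 3 is estimated to give 0.8, with a range from 0.6 to 1.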

Compound 3, intrinsic activity: the largest response reached, as a fraction of the reference agonist's: 0.9
Compound 3: the middle estimate sits 0.10 below what was measured; the measured number falls inside the stated range.
By their numbers in this assay, from the lowest: compounds 2, 1 and 3 (each within the scatter of the next).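

In this assay, within the data shown here, the nitrile on this aromatic carbon, ortho to a 3,5-dimethylpiperazin-1-yl group, gives the first reading for a cyano group here, and a number 0.10 higher from compound 2 to compound 3 (within the scatter) shows that replacing hydrogen with it leaves the maximal response within the usual scatter. Cyano in place of methoxy at the same position gives no change at the digits printed from compound 1 to compound 3 (within the scatter) and is also within the scatter, so hydrogen, methoxy and cyano at this position cannot be told apart on this read-out. No measurement at hand offers an explanation for this flat result.

As far as these compounds go, whether an amine or a carboxylic acid at this position would shift the maximal response beyond the scatter remains open. A longer chain there is equally untested in the compounds shown, and this read-out says nothing about the concentration needed to reach that response.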